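The compounds below may be only part of what the source reports. "The series", "measured", "known", "first", "only" and "open" are said of these compounds alone.

Measured so far in a physicochemical assay for solubility, read by LC-MS, in phosphate buffer, measured as thermodynamic solubility, with a stated time of 24 h, at pH 7.4; a lower number here means a less soluble compound, a higher number a more soluble compound:
compound 1 `Cn1cc(-c2cnc3c(c2)c(-c2cccc(C#N)c2)cn3C)cn1` gives 3000 nM
compound 2 `Cc1ccc(S(=O)(=O)n2cc(-c3cccc(C#N)c3)c3cc(-c4cnn(C)c4)cnc32)cc1` gives 700 nM
compound 3 `Cn1cc(-c2cnc3[nH]cc(-c4ccc(Cl)cc4)c3c2)cn1` gives 800 nM

Compound 3 stands second highest of the three. Its gap to compound 2 lies within the scatter; compound 1 sits higher than compound 3, beyond the scatter. Going by the values given here, the only measured step, a 4.3-fold lower number from compound 1 to compound 2 (0.63 log units; beyond the scatter), concerns a group on an aromatic nitrogen and does not touch the change now at hand.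

Compound 4 `Cn1cc(-c2cnc3[nH]cc(C4CCNC4)c3c2)cn1` differs from compound 3 in one place: pyrrolidin-3-yl in place of 4-chlorophenyl on an aromatic carbon. Among the compounds with values here, no measured step covers this exchange, so the expectation rests on the change itself. The expected step is a 38-fold higher number from compound 3 to compound 4 (1.57 log units; beyond the scatter), upward. Compound 4 is estimated at 30000 nM, with a range from 5000 nM to 200000 nM.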

Compound 4, solubility: 1000000 nM
Compound 4: the middle estimate sits 33-fold (1.52 log units) below what was measured, and the stated range ends below it.
By their numbers in this assay, from the lowest: compounds 2 and 3 (each within the scatter of the next); then compound 1; then compound 4.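

In this assay, going by these compounds alone, the exchange on this aromatic carbon gives a 1300-fold higher number from compound 3 to compound 4 (3.10 log units; beyond the scatter) and so far exceeds the only other step, a 4.3-fold lower number from compound 1 to compound 2 (0.63 log units; beyond the scatter) on an aromatic nitrogen. Within the data shown here, this position therefore moves the read-out over a much wider span than the earlier compounds showed. Nothing on hand explains the size of this step.

As far as these compounds go, whether the step follows the ring nitrogen of pyrrolidin-3-yl or the loss of the 4-chlorophenyl ring remains open. Cyclopentyl, a ring of carbon only, or an open-chain amine on the same aromatic carbon would separate the two.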